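A Hydroxyalkyne Chain Added to the Stronger Compound

The source may report more compounds than this note shows. Statements on the series, on what has been measured and on what is new or still open speak of the compounds shown alone.

Compound 1, `OCC#CCSc1cnc2ccccc2c1SCC#CCCl`: 19.8 ug/mL
Compound 2, `CSc1cnc2ccccc2c1[Se]CC#CCCl`: 3.2 ug/mL

In a functional assay on SW707 cells (Homo sapiens) for antiproliferative activity, with a stated time of 72 h (on this read-out lower numbers stand for stronger inhibition and higher numbers for weaker inhibition), compound 1 gives 19.8 ug/mL, while compound 2 gives 3.2 ug/mL, the lowest of the two numbers; the gap between them lies beyond the usual scatter. Compound 3, `OCC#CCSc1cnc2ccccc2c1[Se]CC#CCCl`, has not yet been measured. It differs from compound 2 by 3-hydroxyprop-1-yn-1-yl in place of hydrogen on a saturated chain carbon bound to a sulfur. Cut one bond further out, the same change reads methyl to 4-hydroxybut-2-yn-1-yl. For the measured compounds named here, no two measured compounds differ in this single place, so the step has no direct precedent. A modest weakening is expected for compound 3, a step of a 1.9-fold higher number from compound 2 to compound 3 (0.27 log units; within the scatter). Compound 3 is estimated at 6 ug/mL, within 2.5 ug/mL to 15 ug/mL.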

Compound 3, concentration for 50% inhibition: 3.3 ug/mL
Compound 3: middle estimate off by 1.8-fold (0.26 log units), on the high side, and the stated range covers the measured number.
By their numbers in this assay, from the lowest: compounds 2 and 3 (each within the scatter of the next); then compound 1.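

In this assay, adding 3-hydroxyprop-1-yn-1-yl in place of hydrogen on a saturated chain carbon bound to a sulfur is tolerated: the result is a 1.0-fold higher number from compound 2 to compound 3 (0.01 log units; within the scatter), so this added chain leaves the reading unchanged within the scatter. For the compounds shown here, with that chain present on both compounds, the group containing selenium rather than the one containing sulfur, on an aromatic carbon, gives a 6.0-fold lower number from compound 1 to compound 3 (0.78 log units; beyond the scatter), the first comparison that isolates this exchange. Nothing measured here explains either result.

As far as these compounds go, whether a longer chain, or an amine or a carboxylic acid in place of the hydroxyl, would be tolerated equally well remains open.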